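Allenyl ether to methyl ether on the shared core

The compounds below may be only part of what the source reports. "The series", "measured", "known", "first", "only" and "open" are said of these compounds alone.

Measured so far:
compound 1 `C=C=CCOc1cc2c(c3c1C[C@@H]1[C@@H](C)CO[C@]1(C)O3)C[C@@H]1[C@@H](C)CO[C@]1(C)O2`, in a functional assay on aorta (Rattus norvegicus, strain Sprague-Dawley) for inhibition (a higher number here means that more compound is needed for the effect, a lower number that less compound is needed), 11000 nM
compound 2 `CC1COC2(C)Oc3c(c4c(c5c3CC3C(C)COC3(C)O5)CC3C(C)COC3(C)O4)CC12`, in this assay 11000 nM

Compound 1 stands level with compound 2 at the digits shown; the two values lie within the scatter of one another, so nothing separates them. Compound 3 `COc1cc2c(c3c1C[C@@H]1[C@@H](C)CO[C@]1(C)O3)C[C@@H]1[C@@H](C)CO[C@]1(C)O2` has not been measured in this assay. From compound 1 to compound 3 the change is hydrogen in place of propa-1,2-dien-1-yl on a saturated chain carbon bound to an oxygen on an aromatic ring. For the measured compounds named here, no measured pair differs in a single place, so this step has no precedent. Compound 3 is expected at 11000 nM, between 4000 nM and 30000 nM. The step estimated here, no change at the digits printed from compound 1 to compound 3 (within the scatter), is expected to be none beyond the scatter.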

Compound 3, half-maximal effective concentration: 33000 nM
The estimate for compound 3 lay 3.0-fold (0.48 log units) below the measured number; the measured number lies above the stated range.
By their numbers in this assay, from the lowest: compounds 1 and 2 (each within the scatter of the next); then compound 3.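

For the compounds shown here, replacing (buta-2,3-dien-1-yl)oxy with methoxy on the shared core gives a 3.0-fold higher number from compound 1 to compound 3 (0.48 log units; beyond the scatter) in this assay, the first single-place comparison. The substituent at this oxygen therefore affects the number, and compound 1 carries the lower value of the pair. Nothing at hand explains the step.

Open, on these data alone, is how butoxy, a saturated chain, would compare with compound 1 and compound 3. As far as these compounds go, that comparison would separate the two double bonds of the buta-2,3-dien-1-yl group from its chain length, and an amine at the end of such a chain also remains open.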